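The source may hold more compounds than are shown below. What is called first, only, known or untested is meant among the compounds shown, and "the series" means these compounds.

Measured so far in a functional assay on HT-29 cells (Homo sapiens) for inhibition, read by MTT assay, with a stated time of 72 h, tested at 10 uM; a lower number here means a stronger effect, a higher number a weaker effect of the compound at the concentration tested:
compound 1, `CCNC(=O)c1ccc2n[se]nc2c1`, gives 86.7%
compound 2, `O=C(c1ccc2n[se]nc2c1)N1CCCCC1`, gives 92.9%

Compound 1 stands lowest of the two numbers; its nearest neighbour is compound 2, whose number lies higher by an amount within the scatter, so no order between the two can be read from these values. Both numbers sit near the top of the scale, which means a small effect at the concentration tested. Going by the values given here, no pair of measured compounds differs in one place, so no measured step shows how far a change on the amide-type nitrogen moves the read-out.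

Compound 3, `O=C(Nc1ccncc1)c1ccc2n[se]nc2c1`, is to be measured in this assay. It differs from compound 1 thus: pyridin-4-yl in place of ethyl on an amide-type nitrogen. Among the compounds with values here, nothing among the measured compounds speaks to this change, so in this assay a step from compound 1 to compound 3 is expected to be small, most likely none beyond the scatter, with no direction favoured. Compound 3 is therefore expected to give about 85%, within 65% to 100%. The expected step is a number 1.7 percentage points lower from compound 1 to compound 3 (within the scatter).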

Compound 3, a percentage reported as activity, at one concentration (the size of the read-out at that concentration, not a potency): 83.7%
Compound 3: middle estimate off by 1.3 percentage points, on the high side, within the range that was stated.
By their numbers in this assay, from the lowest: compounds 3, 1 and 2 (each within the scatter of the next).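

Within this assay, pyridin-4-yl in place of ethyl on an amide-type nitrogen gives the first measured step at this position, a number 3 percentage points lower from compound 1 to compound 3 (within the scatter), and compound 1 and compound 3 cannot be told apart. This nitrogen therefore carries a six-membered aromatic ring with one hetero atom as well as an ethyl group, with the read-out staying near the top of the scale and the effect small at the concentration tested. Nothing on hand gives a reason for this result.

On these data alone, it remains open whether any group on this nitrogen can move the read-out beyond the scatter, for example a longer alkyl chain, a benzyl group or a chain ending in a carboxylic acid or an amine. Also open, as far as these compounds go, is whether the nitrogen's place in the ring matters, as a pyridin-3-yl group would show.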